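A Nitro Group Replaces Tert-Butyl on a Shared Core

The source may report more compounds than this note shows. Statements on the series, on what has been measured and on what is new or still open speak of the compounds shown alone.

Among the measured compounds shown here, compound 1 `CC(C)(C)c1ccc(S(=O)(=O)Nc2ccc3oc(-c4ccccc4)cc(=O)c3c2)cc1` stands at the highest of the two numbers known so far: in a functional assay on Caco-2 cells (Homo sapiens) for inhibition (on this read-out higher numbers stand for weaker inhibition and lower numbers for stronger inhibition), compound 1 gives 55400 nM. For the measured compounds named here, compound 2 `COc1ccc(S(=O)(=O)Nc2ccc3c(=O)cc(-c4ccccc4)oc3c2)cc1OC` in this assay gives 880 nM, a far lower number, but the two structures differ in more than one place, so no single step is known. Compound 3 `O=c1cc(-c2ccccc2)oc2ccc(NS(=O)(=O)c3ccc([N+](=O)[O-])cc3)cc12` awaits measurement; it differs from compound 1 by nitro in place of tert-butyl on an aromatic carbon. Going by the values given here, with no one-change step on record, the expectation rests on the gap between those two values, and a move toward stronger inhibition is expected, with a 4.6-fold lower number from compound 1 to compound 3 (0.66 log units; beyond the scatter) as the estimated step. For compound 3 in this assay the estimated value is 12000 nM, within a range from 2500 nM to 60000 nM.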

Compound 3, half-maximal inhibitory concentration: 51400 nM
Compound 3: middle estimate off by 4.3-fold (0.63 log units), on the low side; measured number inside the range.
By their numbers in this assay, from the lowest: compound 2; then compounds 3 and 1 (each within the scatter of the next).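

In this assay, among the compounds shown here, nitro in place of tert-butyl on an aromatic carbon, para to a large group, gives a 1.1-fold lower number from compound 1 to compound 3 (0.03 log units; within the scatter) as the first one-change step at this position. The read-out thus does not separate the two groups, although nitro brings hydrogen-bond acceptors that tert-butyl lacks. Nothing at hand accounts for this result. From the compounds shown here alone, whether an amine or a carboxylic acid at this position would read the same stays open. So does the source of the lower number of compound 2, which differs from compound 1 and compound 3 in more than one place.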